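The source may hold more compounds than are shown below. What is called first, only, known or untested is meant among the compounds shown, and "the series" means these compounds.

In a functional assay on FM3A cells (Mus musculus) for cytotoxicity (a higher number here means that more compound is needed for the effect, a lower number that less compound is needed), compound 1 (`COOC1(OOCCCCCCI)CCCCCCCCCCC1`) gives 86000 nM. Compound 2 (`C=C(C)COOC(CCCC)(CCCC)OOC`) gives 15000 nM, which leaves compound 1 with the higher of the two numbers, by a gap beyond the usual scatter. Compound 3 (`C=CCCOOC1(OOC)CCCCCCCCCCC1`) keeps the core of compound 1 and changes one chain, with vinyl in place of 4-iodobutyl on a saturated chain carbon, two bonds along the chain from an oxygen. The new chain ends in a double bond, as does the chain of compound 2 at 15000 nM. Among the compounds with values here, no measured pair isolates this change, so any forecast remains loose. A lower number is expected in this assay, with the estimated step of a 2.9-fold lower number from compound 1 to compound 3 (0.46 log units; beyond the scatter) lying moderately beyond the scatter. For compound 3 the expected value is 30000 nM, with an estimated range from 9000 nM to 80000 nM.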

Compound 3, half-maximal effective concentration: 6000 nM
Compound 3: the middle estimate sits 5.0-fold (0.70 log units) above what was measured; the whole stated range lies above it.
By their numbers in this assay, from the lowest: compound 3; then compound 2; then compound 1.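

In this assay, within the data shown here, placing vinyl in place of 4-iodobutyl on a saturated chain carbon, two bonds along the chain from an oxygen, gives a 14-fold lower number from compound 1 to compound 3 (1.16 log units; beyond the scatter) and shows what the earlier compounds could not: with the rest of compound 1 kept, this one chain change alone moves the number by a large step. No measurement offered here explains why the step is so large.

The step removes the iodine, shortens the chain and adds a double bond all at once, and the compounds shown do not separate these three differences. Going by these compounds, it remains open whether a plain saturated alkyl chain without iodine would give a similar number, and how a longer chain ending in a double bond, or a chain ending in an amine, would compare.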